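Allyl substituent on the shared core: cytotoxicity expectations

A few compounds are considered here, and "the series" means these few. Any claim that something is new, unique, unknown or untested is made for them only; others in the source may bear on it.

Compound 1, `CC1=CC(=O)/C(=C(/C)Nc2ccc3cnn(C)c3c2)C(=O)O1`, compound 2, `CC1=CC(=O)/C(=C(/C)Nc2ccc3cnn(Cc4ccc(C)cc4)c3c2)C(=O)O1`, and compound 3, `CC1=CC(=O)/C(=C(/C)Nc2ccc3c(Cl)nn(C)c3c2)C(=O)O1`, share one core and were all tested in an ADME assay on RAW264.7 cells (Mus musculus) for cytotoxicity, read by resazurin assay, with a stated time of 48 h; on this read-out lower numbers stand for higher toxicity in this test and higher numbers for lower toxicity in this test. In this assay compound 1 gives > 100000 nM, which is a limit of the assay rather than a number. Compound 2 gives > 100000 nM in this assay, again a limit. Compound 3 gives > 100000 nM in this assay, also a limit. Compound 3 therefore stands at the same limit as the two other measured compounds, as summarised by the limit of > 100000 nM in this assay, at which 3 of the 3 values shown sit. The two measured steps, a step that the two limits leave unreadable from compound 1 to compound 2 for the 4-methylphenyl group and a step that the two limits leave unreadable from compound 1 to compound 3 for the chloro group, cannot be sized, since both ends sit at the limit.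

Compound 4, `C=CCn1nc(Cl)c2ccc(N/C(C)=C3\C(=O)C=C(C)OC3=O)cc21`, is not yet measured. It differs from compound 3 by vinyl in place of hydrogen on a saturated chain carbon bound to an aromatic nitrogen. Within the data shown here, no measured step bears directly on this change; the closest is the 4-methylphenyl step on the same saturated chain carbon, which stayed at the limit. The expectation is therefore a step that the limit leaves unreadable from compound 3 to compound 4 of no readable size, with compound 4 most likely remaining at the limit. The estimate for compound 4 in this assay is 150000 nM, with a range from 70000 nM to 400000 nM.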

Compound 4, half-maximal cytotoxic concentration: > 100000 nM
Compound 4: no number, only a limit (the forecaster's own chance of this, stated with the estimate: 85%); the middle value lies beyond the limit too.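

Compound 3 and compound 4 both sit at a limit of the assay rather than at a number, so the change from methyl to allyl between them has no readable size: the limit of > 100000 nM in this assay, at which 4 of the 4 values shown sit.

No compound shown gives an actual number in this assay, which leaves open whether any of these group changes alters cytotoxicity at all.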